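The source may report more compounds than this note shows. Statements on the series, on what has been measured and on what is new or still open speak of the compounds shown alone.

Of the compounds shown here, two have been measured in an ADME assay on microsomes from liver (Canis lupus familiaris) for metabolic stability, read by LC-MS, using NADPH, with a stated time of 10 min, tested at 0.1 uM; a higher number here means faster removal of the compound, a lower number slower removal. Compound 1, `CC1SC(c2cccc(C(=O)NCCCCc3ccccc3)c2)N(c2ccc(C3CC3)cc2)C1=O`, gives 1750 mL.min-1.g-1 in this assay. Compound 2, `COc1ccc(F)cc1N1C(=O)CSC1c1cccc(C(=O)NCCCCn2cccn2)c1`, gives 480 mL.min-1.g-1 in this assay, the lowest of the two numbers; compound 1 sits higher by a margin that lies beyond the usual scatter. Compound 3, `O=C(NCCCCn1cccn1)c1cccc(C2SCC(=O)N2c2ccccn2)c1`, has not yet been measured. Its structure differs from compound 2 in one place: pyridin-2-yl in place of 5-fluoro-2-methoxyphenyl on an amide-type nitrogen in a ring. Within the data shown here, no pair of measured compounds differs in a single place, so there is no measured step from which to read the effect of this change. The data on compounds 1 and 2 alone give no direction for it. Compound 3 is therefore expected to stay close to compound 2, with a step of a 1.4-fold lower number from compound 2 to compound 3 (0.14 log units; within the scatter) that may not reach beyond the scatter. The expected value for compound 3 in this assay is 350 mL.min-1.g-1, within a range of 150 mL.min-1.g-1 to 800 mL.min-1.g-1.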

Compound 3, intrinsic clearance in microsomes: 88.9 mL.min-1.g-1
The estimate for compound 3 lay 3.9-fold (0.60 log units) above the measured number, outside the stated range (below it).
By their numbers in this assay, from the lowest: compound 3; then compound 2; then compound 1.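

Pyridin-2-yl in place of 5-fluoro-2-methoxyphenyl, on the amide-type nitrogen in a ring, gives in this assay the first measured step at this position: a 5.4-fold lower number from compound 2 to compound 3 (0.73 log units; beyond the scatter) and so a change beyond the scatter. With the rest of compound 2 kept, the group at this position alone therefore moves the number clearly, here towards slower removal. The data at hand give no reason for this drop.

The compounds shown leave open whether the ring nitrogen of pyridin-2-yl matters, or whether the loss of the methoxy and fluoro groups is enough, which a plain phenyl, a 2-methoxyphenyl or a pyridin-3-yl at this position could separate. They also leave open whether the same change would have a similar effect on the core of compound 1, which carries a methyl group on its ring.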